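The source may report more compounds than this note shows. Statements on the series, on what has been measured and on what is new or still open speak of the compounds shown alone.

Measured compounds:
- compound 1 `ClCc1ccccc1Cn1cnc2c(Cl)nc(Cl)nc21`: "not determined" (no result reported)
- compound 2 `ClCc1cccc(Cn2cnc3ncnc(Cl)c32)c1`: "not determined" (no result reported)
- compound 3 `ClCc1cccc(Cn2cnc3c(Cl)nc(Cl)nc32)c1`: 1950 nM

Compound 2 stands without a number in a functional assay on SNB-19 cells (Homo sapiens) for cytotoxicity, read by sulforhodamine B assay, with a stated time of 48 h; a lower number here means a stronger inhibitor of growth, a higher number a weaker inhibitor of growth; its entry reports no result, and compound 1 shares that position, so neither of the two offers a point of comparison. The only figure in hand belongs to compound 3, which in this assay gives 1950 nM.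

Compound 4 `ClCc1cccc(Cn2cnc3nc(Cl)nc(Cl)c32)c1` is reached from compound 2 by a single change: chloro in place of hydrogen on an aromatic carbon. Going by the values given here, no step between measured compounds is available, so the size of this change cannot be read from the data, and the direction is open. Among the compounds with values here, because compound 3 gives 1950 nM and is the only measured member of the set, the expectation for compound 4 rests on that single number alone, with a wide margin on either side.

Compound 4 is therefore expected to give about 2500 nM in this assay, with a plausible range from 700 nM to 9000 nM.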

Compound 4, concentration for 50% growth inhibition: 1380 nM
For compound 4 the middle estimate is 1.8-fold (0.26 log units) above the measured one, within the range that was stated.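

No step can be read from compound 2 to compound 4: compound 2 has no single number in this assay, whereas compound 4 gives 1380 nM. The compounds shown leave open what this single change does in this assay. No other data shown here bear on this result.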